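From 2-chlorophenyl to 4-fluorophenyl: an expected gain

A few compounds are considered here, and "the series" means these few. Any claim that something is new, unique, unknown or untested is made for them only; others in the source may bear on it.

For the measured compounds named here, in a functional assay on A549 cells (Homo sapiens) for antiproliferative activity, read by MTT assay, with a stated time of 72 h (a lower number here means a stronger inhibitor, a higher number a weaker inhibitor), compound 1 `NC1=NC2(CCOCC2)N(OCCCOc2ccc(Cl)cc2)C(N)=N1` gives 360 nM and compound 2 `NC1=NC2(CCOCC2)N(OCCCOc2ccccc2Cl)C(N)=N1` gives 2700 nM, so compound 2 holds the higher of the two numbers known so far. Going by the values given here, the only measured step between them is a 7.5-fold higher number from compound 1 to compound 2 (0.88 log units; beyond the scatter). This modest step lies beyond the scatter and places 2-chlorophenyl in place of 4-chlorophenyl on an oxygen on a saturated carbon.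

Compound 3 `NC1=NC2(CCOCC2)N(OCCCOc2ccc(F)cc2)C(N)=N1` differs from compound 2 in that same place: 4-fluorophenyl in place of 2-chlorophenyl on an oxygen on a saturated carbon. In words, 4-fluorophenyl stands in place of 2-chlorophenyl on an oxygen on a saturated carbon. Among the compounds with values here, the single measured step bears on this change only in part. Within the data shown here, it suggests that leaving the 2-chlorophenyl group could recover much of what a 7.5-fold higher number from compound 1 to compound 2 (0.88 log units; beyond the scatter) shows, but no measured compound carries fluorine, so that exchange remains untested. A somewhat smaller step than the measured one is therefore expected in this assay, toward a lower number. The estimate is a 4.5-fold lower number from compound 2 to compound 3 (0.65 log units; beyond the scatter). Compound 3 is expected at about 600 nM, with an estimated range of 200 nM to 1800 nM.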

Compound 3, half-maximal inhibitory concentration: 1060 nM
For compound 3 the middle estimate is 1.8-fold (0.25 log units) below the measured one; the range from low to high includes it.
By their numbers in this assay, from the lowest: compound 1; then compound 3; then compound 2.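

In this assay, leaving the 2-chlorophenyl group for the 4-fluorophenyl group brings only part of the recovery that the 4-chlorophenyl group of compound 1 reaches, with a 2.5-fold lower number from compound 2 to compound 3 (0.41 log units; beyond the scatter). The third compound also gives this position its first change of halogen alone: fluoro in place of chloro on an aromatic carbon, with the rest of the molecule held the same, gives a 2.9-fold higher number from compound 1 to compound 3 (0.47 log units; beyond the scatter). So among these three compounds the outcome depends on the identity of the halogen as well as on which phenyl group carries it, and compound 1 keeps the lowest number, while nothing available here accounts for either step.

The compounds shown leave open whether a bromine atom or a methoxy group on the aromatic carbon would continue this order from fluoro to chloro, and how an unsubstituted phenyl group would compare with all three. They also leave open whether the higher number seen with the 2-chlorophenyl group would hold for any halogen other than chlorine, or whether a longer chain before the phenoxy group would alter these steps.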